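Replacing the methylpiperazine on the shared core

A few compounds are considered here, and "the series" means these few. Any claim that something is new, unique, unknown or untested is made for them only; others in the source may bear on it.

Compound 1 `Cc1cc(C)c(S(=O)(=O)N2CCC(N3CCN(C)CC3)CC2)c(C)c1` holds the higher of the two numbers in a functional assay on DLD-1 cells (Homo sapiens) for antiproliferative activity, read by CellTiter-Glo, with a stated time of 72 h (a higher number here means a weaker inhibitor, a lower number a stronger inhibitor), where compound 1 gives 1100 nM. Compound 2 `CC1CCN(C2CCN(S(=O)(=O)c3cc(F)c(Br)c(F)c3)CC2)CC1` differs from it in several places; in this assay compound 2 gives 107 nM. Within the data shown here, no single-point step between measured compounds is available. Compound 3 `Cc1cc(C)c(S(=O)(=O)N2CCC(C3OCC(C)CO3)CC2)c(C)c1` carries the change (a group of 7 heavy atoms (5 carbon, 2 oxygen; one six-membered non-aromatic ring with 2 hetero atoms) in place of a group of 7 heavy atoms (5 carbon, 2 nitrogen; one six-membered non-aromatic ring with 2 hetero atoms), on a saturated ring carbon). Among the measured compounds shown here, with no measured step of this kind to lean on, the expectation is a moderate move toward a higher number, beyond the scatter, as a 2.7-fold higher number from compound 1 to compound 3 (0.44 log units; beyond the scatter). Compound 3 is estimated at 3000 nM, expected within 800 nM to 12000 nM.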

Compound 3, half-maximal inhibitory concentration: > 5000 nM
Compound 3: a limit, no number (the forecaster's own chance of this, stated with the estimate: 20%); at least 1.6-fold (0.22 log units) between middle value and limit.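

Among these compounds, on the saturated ring carbon of the shared core, this is the first single change that can be read, and in this assay it gives an at least 4.5-fold higher number from compound 1 to compound 3 (0.65 log units; beyond the scatter). Compound 3 gives > 5000 nM, which is a limit of the assay and not a number. Both groups match in heavy atoms, ring size, hydrogen-bond acceptors and net charge, so these counts alone do not keep the activity of compound 1 at this position.

As far as these compounds go, whether a morpholine on this ring carbon would sit nearer compound 1 or compound 3 stays open. Compound 2 differs from compound 1 in several places, so its value cannot be assigned to any one change.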